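This account rests on a few compounds, and the source may have more. Where it says the series, first, only, none or still open, it means among the compounds named here.

Compound 1 `COc1cccc(NC(=O)Cn2cc(COc3ccc4c(c3)CCC4)nn2)c1` carries a (3-methoxyphenyl)amino group on the amide attached to the shared core. In an ADME assay on HEK293 cells (Homo sapiens) for inhibition, read by MTT assay, with a stated time of 48 h, tested at 25 uM (a higher number here means more inhibition at the concentration tested (going by the name of the read-out), a lower number less inhibition), compound 1 stands at "not determined" (no result reported), so no number for it is available here. Compound 2 `Cc1ccc(-n2cc(COc3ccc4c(c3)CCC4)nn2)cc1` is likewise without a number in this assay, reported as "not determined" (no result reported). Going by the values given here, the only measured point is compound 3 `c1ccc(-n2cc(COc3ccc4c(c3)CCC4)nn2)cc1`, which in this assay gives 23.4%; it shares the core with compound 1 but differs in more than one place, so no single step between the two is sized.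

Compound 4 `COc1ccccc1NC(=O)Cn1cc(COc2ccc3c(c2)CCC3)nn1` is the partner of compound 1 in the step under consideration. The change is 2-methoxyphenyl in place of 3-methoxyphenyl on an amide-type nitrogen. The two compounds have the same atoms, joined differently; the methoxy group moves on the phenyl ring attached to the amide-type nitrogen.

With no number for compound 1 in this assay, the direction of the step cannot be anchored. Nothing in the series points to a change beyond the scatter for this rearrangement, and the expected step in this assay is none beyond the scatter, in either direction.

Resting on compound 3 at 23.4% as the sole measured reference, compound 4 is estimated at 20%, with a range from 5% to 40%.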

Compound 4, a percentage reported as inhibition, at one concentration (the size of the read-out at that concentration, not a potency): 23.4%
Compound 4: middle estimate off by 3.4 percentage points, on the low side; the range from low to high includes it.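

No step can be read between compound 1 and compound 4 in this assay: compound 1 has no number to set against compound 4 at 23.4%. The compounds shown leave open whether going from 3-methoxyphenyl to 2-methoxyphenyl changes the read-out in this assay at all. No supporting evidence bears on this result.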